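Pyridin-4-yl in place of pyridin-3-yl

The source may report more compounds than this note shows. Statements on the series, on what has been measured and on what is new or still open speak of the compounds shown alone.

In a physicochemical assay for solubility, in simulated intestinal fluid, at pH 7.4 (a lower number here means a less soluble compound, a higher number a more soluble compound), compound 2 (`Cn1cc(C(=O)Nc2ccc(-c3cccnc3)c(C(F)(F)F)c2)c(=O)c2ccccc21`) gives 6.7 ug/mL. Compound 3 (`Cn1cc(C(=O)Nc2ccc(-c3ccccn3)c(C(F)(F)F)c2)c(=O)c2cnccc21`) gives the same number, 6.7 ug/mL, and compound 1 (`Cn1cc(C(=O)Nc2ccc(-c3ccccc3)c(C(F)(F)F)c2)c(=O)c2ccccc21`) gives 11 ug/mL, so all three sit within the usual scatter of repeated measurements.

Compound 4 (`Cn1cc(C(=O)Nc2ccc(-c3ccncc3)c(C(F)(F)F)c2)c(=O)c2ccccc21`) has not been measured yet. Its difference from compound 2 is small: pyridin-4-yl in place of pyridin-3-yl on an aromatic carbon. The two have the same atoms, joined differently, and the swap sits on an aromatic carbon ortho to a trifluoromethyl group.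

For the measured compounds named here, only one measured step bears on this place. Pyridin-3-yl in place of phenyl gave a 1.6-fold lower number from compound 1 to compound 2 (0.22 log units; within the scatter). Compound 3 differs from compound 2 in more than one place, so it offers no clean comparison. Going by the values given here, no measurement yet shows pyridin-4-yl. A whole-ring swap stayed within the scatter, so this smaller swap is expected to stay within it too, in no particular direction. The estimated step is a 1.0-fold higher number from compound 2 to compound 4 (0.02 log units; within the scatter). For compound 4 the estimate is 7 ug/mL, with an expected range of 3 ug/mL to 16 ug/mL.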

Compound 4, solubility: 12 ug/mL
Compound 4: middle estimate off by 1.7-fold (0.23 log units), on the low side, and the stated range covers the measured number.
By their numbers in this assay, from the lowest: compounds 2, 3, 1 and 4 (each within the scatter of the next).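

In this assay, for the compounds shown here, the swap of pyridin-3-yl for pyridin-4-yl gives the first reading of where the ring nitrogen sits at this position (a 1.8-fold higher number from compound 2 to compound 4 (0.25 log units; within the scatter)), and moving that one atom changes little. Pyridin-4-yl in place of phenyl (a 1.1-fold higher number from compound 1 to compound 4 (0.04 log units; within the scatter)) also stays within the scatter, so phenyl, pyridin-3-yl and pyridin-4-yl on this carbon, ortho to a trifluoromethyl group, cannot be told apart in this read-out. Nothing measured here explains why the numbers fall as they do.

As far as these compounds go, all three of these groups are six-membered aromatic rings of the same size, so it remains open whether a group of another kind on this carbon, such as a carboxylic acid or a dimethylamino group, would move the number beyond the scatter. From the compounds shown here alone, it is also open whether these small steps would hold on a different core, since compound 3 differs from the others in more than one place and gives no clean comparison.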